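The source may hold more compounds than are shown below. What is called first, only, known or untested is meant among the compounds shown, and "the series" means these compounds.

In a functional assay on SMMC-7721 cells (Homo sapiens) for antiproliferative activity, read by MTT assay, with a stated time of 48 h (a lower number here means a stronger inhibitor, a higher number a weaker inhibitor), three compounds sharing one core have been measured, and they differ only in the group on a double-bonded ring carbon. Compound 1 `CC(C)=CCC[C@]1(C)/C=C/[C@@H](OC(=O)C=C(C)C)[C@](C)(O)/C=C/C(=O)/C(C(=O)O)=C\C1`, which carries carboxy there, gives only a limit, > 10000 nM. Compound 2 `CCN(CC)C/C1=C/C[C@](C)(CCC=C(C)C)/C=C/[C@@H](OC(=O)C=C(C)C)[C@](C)(O)/C=C/C1=O`, with (diethylamino)methyl, gives 570 nM. Compound 3 `CC(C)=CCC[C@]1(C)/C=C/[C@@H](OC(=O)C=C(C)C)[C@](C)(O)/C=C/C(=O)/C(CN=[N+]=[N-])=C\C1`, with azidomethyl, gives 3080 nM, the higher of the two actual numbers in the set.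

Compound 4 `CC(C)=CCC[C@]1(C)/C=C/[C@@H](OC(=O)C=C(C)C)[C@](C)(O)/C=C/C(=O)/C(Cn2cc(CO)nn2)=C\C1` keeps everything in compound 3 except the azido group: 4-(hydroxymethyl)-1H-1,2,3-triazol-1-yl in place of azido on a saturated chain carbon bound to a double-bonded ring carbon. The 4-(hydroxymethyl)-1H-1,2,3-triazol-1-yl group takes its place on a saturated chain carbon bound to a double-bonded ring carbon.

The measured steps all concern this same place. They are an at least 17-fold lower number from compound 1 to compound 2 (1.24 log units; beyond the scatter), an at least 3.2-fold lower number from compound 1 to compound 3 (0.51 log units; beyond the scatter) and a 5.4-fold higher number from compound 2 to compound 3 (0.73 log units; beyond the scatter). They show that the number in this assay moves with the group here, but none of them involves a triazole, so they give no direction for this change. With compound 3 at 3080 nM as the nearest starting point, no step beyond the scatter is expected, although a modest one in either direction remains possible. The expected change is a 1.1-fold higher number from compound 3 to compound 4 (0.06 log units; within the scatter). For compound 4 the estimated value is 3500 nM, with an expected range from 1000 nM to 9000 nM.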

Compound 4, half-maximal inhibitory concentration: 3560 nM
For compound 4 the middle estimate is 1.0-fold (0.01 log units) below the measured one, and the stated range covers the measured number.
By their numbers in this assay, from the lowest: compound 2; then compounds 3 and 4 (each within the scatter of the next). At a limit, above all of these: compound 1.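

In this assay, the step reads a 1.2-fold higher number from compound 3 to compound 4 (0.06 log units; within the scatter), so on a saturated chain carbon bound to a double-bonded ring carbon the azido group and the 4-(hydroxymethyl)-1H-1,2,3-triazol-1-yl group cannot be told apart, even though the entering group brings a five-membered aromatic ring and a hydrogen-bond donor. The diethylamino group of compound 2 stands apart from this new group as it does from azido, with a 6.2-fold higher number from compound 2 to compound 4 (0.80 log units; beyond the scatter), so of the three groups compared on this carbon, diethylamino alone separates from the others. Compound 1 gives only a limit, and against it the change reads an at least 2.8-fold lower number from compound 1 to compound 4 (0.44 log units; beyond the scatter), which makes the triazole the second group on this carbon whose compound gives an actual number where the carboxy compound gives a limit: the limit of > 10000 nM in this assay, at which 1 of the 4 values shown sits.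

Going by these compounds, it remains open whether another amine on this carbon, such as morpholine or dimethylamino, would sit with compound 2 or with compound 3 and compound 4. Also open, on these data alone, is whether the hydroxymethyl on the triazole matters at all, or whether a phenyl or a longer alkyl chain in its place would give a different number.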